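Series notes: tetrazolylsulfanyl additions and persistence at neutral pH

The source may report more compounds than this note shows. Statements on the series, on what has been measured and on what is new or still open speak of the compounds shown alone.

Among the measured compounds shown here, compound 3 `CO[C@H]1C(=O)N2C(C(=O)c3ccccc3)=C(C)[C@@H](Sc3nnnn3C)S(=O)(=O)C12` gives 200 h in a physicochemical assay, at pH 7.4 (a higher number here means that the compound lasts longer, a lower number that the compound disappears faster), the highest of the three numbers measured so far. Compound 1 `CO[C@H]1C(=O)N2C(C(=O)c3ccccc3)=C(C)CS(=O)(=O)C12` gives 26 h in this assay, and compound 2 `CO[C@H]1C(=O)N2C(C(=O)c3ccccc3)=C(CSc3nnnn3C)CS(=O)(=O)C12` gives 17 h in this assay; the step of a 7.7-fold higher number from compound 1 to compound 3 (0.89 log units; beyond the scatter) sets compound 3 apart. Compound 4 `CO[C@H]1C(=O)N2C(C(=O)c3ccccc3)=C(CSc3nnnn3C)[C@@H](Sc3nnnn3C)S(=O)(=O)C12` differs from compound 3 by (1-methyl-1H-tetrazol-5-yl)sulfanyl in place of hydrogen on a saturated chain carbon bound to a double-bonded ring carbon. For the measured compounds named here, the one measured step that bears on this change is the step of a 1.5-fold lower number from compound 1 to compound 2 (0.18 log units; within the scatter), the same change made on compound 1, which stayed within the scatter. The step of a 1.3-fold lower number from compound 3 to compound 4 (0.12 log units; within the scatter) is therefore expected to be small in this assay, if anything toward a lower number. Compound 4 is estimated at 150 h in this assay, within the range 60 h to 400 h.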

Compound 4, half-life: 1400 h
Estimate against measurement, compound 4: 9.3-fold (0.97 log units) below; measured number outside the range, above it.
By their numbers in this assay, from the lowest: compounds 2 and 1 (each within the scatter of the next); then compound 3; then compound 4.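

In this assay the change on the saturated chain carbon gives a 7.0-fold higher number from compound 3 to compound 4 (0.85 log units; beyond the scatter) when the saturated ring carbon already carries (1-methyl-1H-tetrazol-5-yl)sulfanyl, whereas with hydrogen there it gave a 1.5-fold lower number from compound 1 to compound 2 (0.18 log units; within the scatter) and stayed within the scatter. The two changes are thus not independent: the ring-carbon change gives an 82-fold higher number from compound 2 to compound 4 (1.92 log units; beyond the scatter) with the chain group present, against a 7.7-fold higher number from compound 1 to compound 3 (0.89 log units; beyond the scatter) without it. No measurement at hand accounts for this dependence.

Still open, from the compounds shown here alone, is whether the rise is specific to this group. A carboxylic acid or an amine on the saturated chain carbon of compound 3 would test that.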